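Aryl exchange on the shared core of compound 1

The source may report more compounds than this note shows. Statements on the series, on what has been measured and on what is new or still open speak of the compounds shown alone.

Working notes on the series. Compound 1 `CCCSc1nc(N/N=C/c2cccnc2)c2nnn(Cc3ccccc3)c2n1` carries pyridin-3-yl on a carbon with a double bond to nitrogen. In a functional assay on ECa-109 cells (Homo sapiens) for antiproliferative activity, read by MTT assay, with a stated time of 72 h (on this read-out lower numbers stand for stronger inhibition and higher numbers for weaker inhibition), compound 1 gives > 64000 nM, which is a limit of the assay rather than a number (the limit of > 64000 nM in this assay, at which 1 of the 3 values shown sits). The comparators are compound 2 `C#CCSc1nc(N/N=C/c2ccc(N(C)C)cc2)c2nnn(Cc3ccccc3)c2n1` and compound 3 `C#CCSc1nc(N/N=C/c2c(O)ccc3ccccc23)c2nnn(Cc3ccccc3)c2n1`; in this assay compound 2 gives 31300 nM and compound 3 gives 6520 nM. Among the compounds with values here, their one-place step, a 4.8-fold lower number from compound 2 to compound 3 (0.68 log units; beyond the scatter), is the only measured aryl exchange and sits on a different sulfur chain, so it bears on the present change only loosely. Compound 4 `CCCSc1nc(N/N=C/c2ccc(Br)cc2)c2nnn(Cc3ccccc3)c2n1` differs from compound 1 by 4-bromophenyl in place of pyridin-3-yl on a carbon with a double bond to nitrogen. Since compound 1 offers only a limit, the size of any gain cannot be read from the data; a modest lowering is expected, the step being an at least 1.6-fold lower number from compound 1 to compound 4 (0.20 log units; that floor lies within the scatter). Compound 4 is expected to give 40000 nM, between 12000 nM and 130000 nM.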

Compound 4, half-maximal inhibitory concentration: > 64000 nM
Compound 4 gave a limit, no number; the forecaster's own chance of this, stated with the estimate: 40%; at least 1.6-fold (0.20 log units) between middle value and limit.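

Compound 1 and compound 4 both sit at a limit of this assay, not at a number, so no step between them can be read: the limit of > 64000 nM in this assay, at which 2 of the 4 values shown sit.

The compounds shown leave open whether any aryl exchange on the shared core of compound 1 gives a measurable value.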